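Swapping a Methyl for a Pyridinyl on a Ring Nitrogen

This account rests on a few compounds, and the source may have more. Where it says the series, first, only, none or still open, it means among the compounds named here.

Compound 3 `CNc1nc(SCc2nc3ccccc3[nH]2)nc(-c2ccccc2)c1C#N` gives 3.28 nM in a functional assay on GOTO cells (Homo sapiens) for cytotoxicity, read by MTT assay, with a stated time of 3 days (a lower number here means a stronger inhibitor, a higher number a weaker inhibitor), the second highest of three numbers: compound 2 `N#Cc1c(NN)nc(SCc2nc3ccccc3[nH]2)nc1-c1ccccc1` gives 2.68 nM and compound 1 `N#Cc1c(O)nc(SCc2nc3ccccc3[nH]2)nc1-c1ccccc1` gives 7.81 nM. The steps of a 2.9-fold lower number from compound 1 to compound 2 (0.46 log units; beyond the scatter) and a 2.4-fold lower number from compound 1 to compound 3 (0.38 log units; beyond the scatter) show that replacing hydroxy on an aromatic carbon with a nitrogen group matters modestly, while a 1.2-fold higher number from compound 2 to compound 3 (0.09 log units; within the scatter) shows that changing the group on that nitrogen made no difference beyond the scatter. Compound 4 `N#Cc1c(Nc2ccccn2)nc(SCc2nc3ccccc3[nH]2)nc1-c1ccccc1` differs from compound 3 by pyridin-2-yl in place of methyl on a nitrogen on an aromatic ring. Among the compounds with values here, the only measured step on that nitrogen is small, and no measured compound carries an aromatic ring on that nitrogen, so the expected step of a 1.1-fold higher number from compound 3 to compound 4 (0.03 log units; within the scatter) is small and its direction is uncertain. Compound 4 is therefore expected to give 3.5 nM, within 1.2 nM to 10 nM.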

Compound 4, half-maximal inhibitory concentration: 2.5 nM
For compound 4 the middle estimate is 1.4-fold (0.15 log units) above the measured one; the measured number falls inside the stated range.
By their numbers in this assay, from the lowest: compounds 4, 2 and 3 (each within the scatter of the next); then compound 1.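

A whole aromatic ring fits on this nitrogen without a change beyond the scatter: pyridin-2-yl in place of methyl leaves the number where it was (a 1.3-fold lower number from compound 3 to compound 4 (0.12 log units; within the scatter)), and the same holds for pyridin-2-yl in place of amino (a 1.1-fold lower number from compound 2 to compound 4 (0.03 log units; within the scatter)). The step away from hydroxy also stays beyond the scatter with this larger group (a 3.1-fold lower number from compound 1 to compound 4 (0.49 log units; beyond the scatter)). No measurement here explains this tolerance.

Still open, from the compounds shown here alone, is whether phenyl, which lacks the ring nitrogen of pyridin-2-yl, would give a similar number, and whether a longer chain such as hexyl or a group carrying a carboxylic acid would fit on this nitrogen.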